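The source may report more compounds than this note shows. Statements on the series, on what has been measured and on what is new or still open speak of the compounds shown alone.

Values in an ADME assay on cells (spleen, Mus musculus, strain C57BL/6) for inhibition, read by flow cytometry and propidium iodide staining, with a stated time of 24 h, at 37 degrees C; on this read-out higher numbers stand for an effect only at larger amounts of compound and lower numbers for an effect already at smaller amounts:
Compound 1 `O=C(Cn1cc(CO)nn1)NCc1ccccc1`: 490 uM
Compound 2 `O=C(O)CCCCc1cn(CC(=O)NCc2ccccc2)nn1`: 1080 uM
Compound 3 `Cc1ccccc1-c1cn(CC(=O)NCc2ccccc2)nn1`: 940 uM

The number for compound 3 lies within the scatter of both other values, as a 1.9-fold higher number from compound 1 to compound 3 (0.28 log units; within the scatter) and a 1.1-fold lower number from compound 2 to compound 3 (0.06 log units; within the scatter) show. Of the three measured steps, only a 2.2-fold higher number from compound 1 to compound 2 (0.34 log units; beyond the scatter) passes the scatter, and it does so modestly.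

Compound 4 `COc1cccc(-c2cn(CC(=O)NCc3ccccc3)nn2)c1` has 3-methoxyphenyl in place of the 2-methylphenyl of compound 3, on an aromatic carbon of a five-membered aromatic ring with 3 nitrogen: 3-methoxyphenyl in place of 2-methylphenyl on an aromatic carbon. Both groups have one six-membered aromatic ring of carbon only. Among the measured compounds shown here, no measured compound carries 3-methoxyphenyl, and no measured pair compares two substituted phenyl groups, so the evidence is indirect.

The closest steps are the two that introduce 2-methylphenyl. Neither a 1.9-fold higher number from compound 1 to compound 3 (0.28 log units; within the scatter) nor a 1.1-fold lower number from compound 2 to compound 3 (0.06 log units; within the scatter) goes beyond the scatter, although each replaces a quite different group. A step beyond the scatter is therefore not expected in this assay, and no direction is favoured. The estimated step is a 1.2-fold lower number from compound 3 to compound 4 (0.07 log units; within the scatter). For compound 4 the estimated value is 800 uM, with an expected range of 450 uM to 1400 uM.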

Compound 4, concentration for half-maximal effect: 840 uM
For compound 4 the middle estimate is 1.1-fold (0.02 log units) below the measured one, within the range that was stated.
By their numbers in this assay, from the lowest: compounds 1, 4, 3 and 2 (each within the scatter of the next, the first and the last beyond it).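

In this assay, among the compounds shown here, this is the first comparison of two substituted phenyl groups on an aromatic carbon of the five-membered aromatic ring with 3 nitrogen, and 3-methoxyphenyl, which brings 1 oxygen and 1 hydrogen-bond acceptor, does not separate from 2-methylphenyl (a 1.1-fold lower number from compound 3 to compound 4 (0.05 log units; within the scatter)). For the compounds shown here, compound 4 also stays within the scatter of the two compounds with non-aromatic groups at this place (a 1.3-fold lower number from compound 2 to compound 4 (0.11 log units; within the scatter); a 1.7-fold higher number from compound 1 to compound 4 (0.23 log units; within the scatter)), so the only step beyond the scatter remains the modest one between those two compounds (a 2.2-fold higher number from compound 1 to compound 2 (0.34 log units; beyond the scatter)). No measurement offers an explanation for these numbers.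

The compounds shown leave open whether the methoxy group or its place on the phenyl ring has any effect of its own, since compound 3 and compound 4 differ in both, and a 2-methoxyphenyl or 3-methylphenyl group would separate the two. They also leave open whether any group at this place, such as an aminomethyl group or an unsubstituted phenyl ring, would bring the number clearly below that of the other compounds.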